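The source may report more compounds than this note shows. Statements on the series, on what has been measured and on what is new or still open speak of the compounds shown alone.

Working notes on the series. Compound 1 `CC(C)NC(=O)c1cc(Oc2cccc(NC(=S)Nc3ccc(Cl)cc3)c2)ccn1` and compound 2 `CCNC(=O)c1cc(Oc2cccc(NC(=S)Nc3ccc(F)c(F)c3)c2)ccn1` share a core and were both tested in a functional assay on HCT-116 cells (Homo sapiens) for cytotoxicity, read by MTT assay, with a stated time of 48 h; a higher number here means a weaker inhibitor, a lower number a stronger inhibitor. Compound 1 gives 22100 nM; compound 2 gives 30300 nM. The two figures lie within the scatter of each other, so compound 2 stands alongside compound 1 with no separation that the data can support. Among the measured compounds shown here, no step between measured compounds has been worked out for this pair.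

Compound 3 `O=C(c1cc(Oc2cccc(NC(=S)Nc3ccc(F)c(F)c3)c2)ccn1)N1CCCC1` has not yet been measured. It differs from compound 2 by pyrrolidin-1-yl in place of ethylamino on a carbonyl carbon. For the measured compounds named here, no measured step in this assay bears on such a change, so no direction can be read from the two values; the step from compound 2 to compound 3 is expected to be a 1.1-fold higher number from compound 2 to compound 3 (0.02 log units; within the scatter), within the scatter. Compound 3 is therefore estimated at 32000 nM, with a range from 12000 nM to 85000 nM.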

Compound 3, half-maximal inhibitory concentration: 52000 nM
Beside the measured number, compound 3's estimate is 1.6-fold (0.21 log units) below it; the measured number falls inside the stated range.
By their numbers in this assay, from the lowest: compounds 1, 2 and 3 (each within the scatter of the next, the first and the last beyond it).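

In this assay, the first step measured at this position, a 1.7-fold higher number from compound 2 to compound 3 (0.23 log units; within the scatter), stays within the scatter. Pyrrolidin-1-yl in place of ethylamino on a carbonyl carbon removes the amide hydrogen and brings in a five-membered non-aromatic ring, yet the data support no separation between the two compounds. Nothing measured here accounts for the size of this step.

The compounds shown leave open whether a six-membered amine such as piperidin-1-yl or morpholin-4-yl, or a carboxylic acid in place of the amide, would give a number separated from that of compound 2. They also leave open whether the same exchange would read alike with the 4-chlorophenyl group of compound 1 on the thiourea.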